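This account rests on a few compounds, and the source may have more. Where it says the series, first, only, none or still open, it means among the compounds named here.

In an ADME assay (liver) for metabolic stability, with Liver microsome (Rattus norvegicus) as the target, using microsomes and NADPH, with a stated time of 30 min (a lower number here means slower removal, a higher number faster removal of the compound), compound 1 `CC#C[C@H]1CN(S(=O)(=O)c2ccc(N)nc2)CCN1c1ccc(C(O)(COC)C(F)(F)F)cc1` gives 93 mL.min-1.g-1 and compound 2 `CC#C[C@H]1CN(S(=O)(=O)c2ccc(N)nc2)CCN1c1ccc(C(O)(CC#N)C(F)(F)F)cc1` gives 57 mL.min-1.g-1 and these two numbers lie within the usual scatter of each other, which leaves compound 2 level with compound 1. Within the data shown here, the one measured step, cyano in place of methoxy on a saturated chain carbon, is a 1.6-fold lower number from compound 1 to compound 2 (0.21 log units; within the scatter) and it touched only part of the group that now leaves altogether. Among the measured compounds shown here, compound 3 `CC#C[C@H]1CN(S(=O)(=O)c2ccc(N)nc2)CCN1c1ccc([S+](C)[O-])cc1` carries a far larger change, a group of 3 heavy atoms (1 carbon, 1 oxygen, 1 sulfur; no ring) in place of a group of 9 heavy atoms (4 carbon, 1 nitrogen, 1 oxygen, 3 fluorine; no ring), on an aromatic carbon and no measured step shows such a replacement. The data therefore give no direction, and no shift beyond the scatter is expected in this assay with low confidence. The estimated change is a 1.1-fold lower number from compound 2 to compound 3 (0.06 log units; within the scatter) and it remains uncertain. For compound 3 the expected value is 50 mL.min-1.g-1 with an estimated range from 17 mL.min-1.g-1 to 120 mL.min-1.g-1 on this limited evidence.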

Compound 3, intrinsic clearance in microsomes: 17 mL.min-1.g-1
For compound 3 the middle estimate is 2.9-fold (0.47 log units) above the measured one; measured number inside the range.
By their numbers in this assay, from the lowest: compound 3; then compounds 2 and 1 (each within the scatter of the next).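

In this assay, both a 3.4-fold lower number from compound 2 to compound 3 (0.53 log units; beyond the scatter) and a 5.5-fold lower number from compound 1 to compound 3 (0.74 log units; beyond the scatter) follow when the whole group on the aromatic carbon is replaced by the small sulfur-containing group of compound 3. This position therefore tolerates a change that moves the number beyond the scatter, which the earlier swap at the end of the chain, a change within only part of that group, did not do. Nothing here gives a measured reason for the lower number.

Since the large group leaves as a whole and the new group enters in the same step, these compounds cannot show which part of the exchange matters. They also leave open whether another small group on this aromatic carbon, such as an amine or a carboxylic acid, would give a similarly low number.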